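The compounds below may be only part of what the source reports. "The series", "measured", "known", "first", "only" and "open" are said of these compounds alone.

Measured in a functional assay on HL-60 cells (Homo sapiens) for inhibition, read by MTT assay, with a stated time of 72 h; on this read-out higher numbers stand for weaker inhibition and lower numbers for stronger inhibition:
Compound 1 `Cc1ccc(C)c(N2CCN(C(=O)c3oc(C)nc3-c3ccc(F)cc3)CC2)c1`: 358 nM
Compound 2 `Cc1nc(-c2ccccc2)c(C(=O)N2CCN(c3cccc(C)c3C)CC2)o1`: 35 nM

Compound 2 stands lowest of the two, and the gap to compound 1 lies beyond the scatter. Compound 3 `Cc1ccc(C)c(N2CCN(C(=O)c3oc(C)nc3-c3ccccc3)CC2)c1` has 2,5-dimethylphenyl in place of 2,3-dimethylphenyl on an amine nitrogen in a ring. Going by the values given here, no measured pair shows this change alone. However, compound 1, which also carries 2,5-dimethylphenyl, gives 358 nM, so a moderate rise beyond the scatter is expected in this assay. The expected step is a 4.3-fold higher number from compound 2 to compound 3 (0.63 log units; beyond the scatter). For compound 3 the estimate is 150 nM, with an expected range of 40 nM to 500 nM.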

Compound 3, half-maximal inhibitory concentration: 31.3 nM
Beside the measured number, compound 3's estimate is 4.8-fold (0.68 log units) above it; measured number below the stated range.
By their numbers in this assay, from the lowest: compounds 3 and 2 (each within the scatter of the next); then compound 1.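

In this assay, 2,5-dimethylphenyl in place of 2,3-dimethylphenyl on the amine nitrogen in the ring gives a 1.1-fold lower number from compound 2 to compound 3 (0.05 log units; within the scatter), so the assay does not separate these two groups. The large gap instead appears with hydrogen in place of fluoro on an aromatic carbon, which gives an 11-fold lower number from compound 1 to compound 3 (1.06 log units; beyond the scatter). No measurement here explains either step. Still open, going by these compounds, is whether chloro or methoxy on that aromatic carbon would track with fluoro or with hydrogen. Also open, on these data alone, is whether a plain phenyl on the amine nitrogen would fit with these dimethylphenyl groups.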